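A dibromo step from compound 3 to compound 4

The compounds below may be only part of what the source reports. "The series", "measured", "known", "first", "only" and "open" are said of these compounds alone.

Compound 1 `C/C(=N\NC(=O)c1cccc(S(=O)(=O)N2CCOCC2)c1)c1cccc(O)c1` gives > 100000 nM (a limit)
Compound 2 `C/C(=N\NC(=O)c1cccc(S(=O)(=O)N2CCOCC2)c1)c1cc(Br)ccc1O` gives 7830 nM
Compound 3 `O=C(N/N=C/c1ccccc1O)c1cccc(S(=O)(=O)N2CCOCC2)c1` gives 29100 nM

In a functional assay on MCF7 cells (Homo sapiens) for antiproliferative activity, read by MTT assay, with a stated time of 72 h (on this read-out higher numbers stand for weaker inhibition and lower numbers for stronger inhibition), compound 3 stands at 29100 nM and compound 2 lower at 7830 nM (a gap beyond the scatter). Compound 1 offers only a limit. Compound 4 `O=C(N/N=C/c1cc(Br)cc(Br)c1O)c1cccc(S(=O)(=O)N2CCOCC2)c1` carries 3,5-dibromo-2-hydroxyphenyl in place of 2-hydroxyphenyl on a carbon with a double bond to nitrogen. Among the compounds with values here, the one measured step that bears on this is large: an at least 12-fold lower number from compound 1 to compound 2 (1.10 log units; beyond the scatter). That step brought in 5-bromo-2-hydroxyphenyl but replaced 3-hydroxyphenyl, so it is not a clean guide to bromine alone. A moderate move to a lower number is therefore expected: a 3.6-fold lower number from compound 3 to compound 4 (0.56 log units; beyond the scatter). Compound 4 is estimated at 8000 nM (expected range 2500 nM to 22000 nM).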

Compound 4, half-maximal inhibitory concentration: 16000 nM
For compound 4 the middle estimate is 2.0-fold (0.30 log units) below the measured one; measured number inside the range.
By their numbers in this assay, from the lowest: compound 2; then compounds 4 and 3 (each within the scatter of the next). At a limit, above all of these: compound 1.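

In this assay, 3,5-dibromo-2-hydroxyphenyl in place of 2-hydroxyphenyl gives a 1.8-fold lower number from compound 3 to compound 4 (0.26 log units; within the scatter), so on this carbon with a double bond to nitrogen the two bromines do not separate the pair. The large at least 12-fold lower number from compound 1 to compound 2 (1.10 log units; beyond the scatter), which also replaced 3-hydroxyphenyl, therefore does not carry over to this bromine change. Nothing shown accounts for this outcome. The compounds shown leave open whether chlorine in place of the bromines, or a methoxy group or an amine on this ring, would give a step beyond the scatter.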